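The source may hold more compounds than are shown below. What is called first, only, known or untested is meant among the compounds shown, and "the series" means these compounds.

Of the compounds shown here, three have been read in a physicochemical assay for solubility, read by chemiluminescence, in phosphate buffer, measured as kinetic solubility, at pH 7.4; a higher number here means a more soluble compound, a lower number a less soluble compound. Compound 1 `Cc1cc(C)n(Cc2ccc(C(=O)NCC3(c4ccccn4)CCOCC3)cc2)n1` reports only a limit, >= 445000 nM, and not a number. Compound 2 `Cc1cc(C)n(-c2ccc(C(=O)NCC3(c4nc(-c5ccccc5)cs4)CCOCC3)cc2)n1` gives 33000 nM, the lower of the two numbers available. Compound 3 `COc1cccc(-c2csc(C3(CNC(=O)c4ccc(Cn5nc(C)cc5C)cc4)CCOCC3)n2)c1` gives 72000 nM, and its gap to compound 2 lies beyond the scatter.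

Compound 4 `Cn1c(Nc2ccc(C(=O)NCC3(c4nc(-c5ccccc5)cs4)CCOCC3)cc2)nc2ccccc21` has not yet been measured. It differs from compound 2 in one place: (1-methyl-1H-benzimidazol-2-yl)amino stands in place of 3,5-dimethyl-1H-pyrazol-1-yl on an aromatic carbon, para to a large group ((1-methyl-1H-benzimidazol-2-yl)amino in place of 3,5-dimethyl-1H-pyrazol-1-yl on an aromatic carbon). Going by the values given here, no measured pair isolates this change, so the expectation is a judgement with a wide margin. A moderate downward move in this assay is expected, beyond the scatter but not large. The expected step is a 2.8-fold lower number from compound 2 to compound 4 (0.44 log units; beyond the scatter). Compound 4 is estimated at 12000 nM, with an expected range of 3000 nM to 40000 nM.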

Compound 4, solubility: 10000 nM
Beside the measured number, compound 4's estimate is 1.2-fold (0.08 log units) above it; the range from low to high includes it.
By their numbers in this assay, from the lowest: compound 4; then compound 2; then compound 3. At a limit, above all of these: compound 1.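

Going by these compounds alone, compound 2 and compound 4 form the first pair that differ in one place: on an aromatic carbon, para to a large group, in this assay, (1-methyl-1H-benzimidazol-2-yl)amino in place of 3,5-dimethyl-1H-pyrazol-1-yl gives a 3.3-fold lower number from compound 2 to compound 4 (0.52 log units; beyond the scatter) with the rest of the structure held constant. The entering group has more heavy atoms and adds a hydrogen-bond donor, so this single pair changes size and donor count together. Nothing in the data at hand accounts for the step.

On these data alone, it remains open whether the lower number goes with the amino part of the entering group or with its benzimidazole. A plain amine or a carboxylic acid on the same aromatic carbon would test this position with a group lacking any second ring.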